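The source may report more compounds than this note shows. Statements on the series, on what has been measured and on what is new or still open speak of the compounds shown alone.

Working notes on the spiro series built on the shared core of compound 1, whose structure is `Cc1ccccc1-n1nncc1CN1C(=O)C2(C(C#N)=C(N)Oc3c2c2nc4ccccc4nc2c2ccccc32)c2ccccc21`. In a functional assay on HepG2 cells (Homo sapiens) for antiproliferative activity, read by MTT assay, with a stated time of 48 h (a higher number here means a weaker inhibitor, a lower number a stronger inhibitor), compound 1 gives > 50000 nM, which is a limit of the assay and not a number. Compound 2, `N#CC1=C(N)Oc2c(c3nc4ccccc4nc3c3ccccc23)C12C(=O)N(Cc1cnnn1-c1cccc(Cl)c1)c1ccccc12`, carries 3-chlorophenyl on the triazole nitrogen; in this assay compound 2 gives > 50000 nM, again a limit. Compound 3, `N#CC1=C(N)Oc2c(c3nc4ccccc4nc3c3ccccc23)C12C(=O)N(Cc1cnnn1-c1cccc(Br)c1)c1ccccc12`, carries 3-bromophenyl instead; in this assay compound 3 gives > 50000 nM, also a limit. The steps a step that the two limits leave unreadable from compound 1 to compound 2, a step that the two limits leave unreadable from compound 1 to compound 3 and a step that the two limits leave unreadable from compound 2 to compound 3 therefore cannot be sized, since (the limit of > 50000 nM in this assay, at which 3 of the 3 values shown sit).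

Compound 4, `N#CC1=C(N)Oc2c(c3nc4ccccc4nc3c3ccccc23)C12C(=O)N(Cc1cnnn1-c1ccc(N)cc1)c1ccccc12`, differs from compound 2 by 4-aminophenyl in place of 3-chlorophenyl on an aromatic nitrogen. Among the measured compounds shown here, nothing measured bears on a change of this kind: all three aryl variants sit at the limit, so no step in this assay can be read off, and no direction can be assigned beyond the scatter. For compound 4 the expectation in this assay is that it stays at the limit as well, with an estimated value of 60000 nM, the range 20000 nM to 200000 nM, and the step that the limit leaves unreadable from compound 2 to compound 4 is expected to be unreadable in the same way.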

Compound 4, half-maximal inhibitory concentration: > 50000 nM
Compound 4: a limit, no number; the forecaster's own chance of this, stated with the estimate: 80%; the middle value does not contradict the limit.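

In this assay compound 4 also gives a limit and not a number, so its steps to compound 1, compound 2 and compound 3 cannot be read: the limit of > 50000 nM in this assay, at which 4 of the 4 values shown sit. The compounds shown leave open whether changing the aryl group on the triazole nitrogen shifts activity at all, and in which direction.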